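Swapping an aromatic pyridine arm for a piperidine chain

The source may report more compounds than this note shows. Statements on the series, on what has been measured and on what is new or still open speak of the compounds shown alone.

Three compounds sharing one core were tested in an assay on HEK293 cells for inhibition of Steryl-sulfatase (Homo sapiens), tested at 1 uM; on this read-out higher numbers stand for a stronger effect at the one concentration tested and lower numbers for a weaker effect. Compound 1 `NS(=O)(=O)Oc1ccc2c(c1)CN(C(=O)c1ccc(N3CCN(Cc4ccccc4)CC3)cc1)CC2` gives 75.8%, compound 2 `CCN(Cc1ccccn1)c1ccc(C(=O)N2CCc3ccc(OS(N)(=O)=O)cc3C2)cc1` gives 87.7%, and compound 3 `CCN(Cc1ccncc1)c1cccc(C(=O)N2CCc3ccc(OS(N)(=O)=O)cc3C2)c1` gives 52.8%. On these numbers compound 3 stands lowest: its nearest neighbour is compound 1, whose value sits higher by a margin beyond the usual scatter, and compound 2 lies further above it, also beyond the scatter.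

The next compound, compound 4 `CN(CCN1CCCCC1)c1cccc(C(=O)N2CCc3ccc(OS(N)(=O)=O)cc3C2)c1`, is built from compound 3 by one change: methyl(2-(piperidin-1-yl)ethyl)amino in place of ethyl((pyridin-4-yl)methyl)amino on an aromatic carbon. The part that leaves holds a six-membered aromatic ring with one hetero atom; the part that enters holds a six-membered non-aromatic ring with one hetero atom, attached through a two-carbon chain, while the count of heavy atoms, donors and acceptors stays the same.

For the measured compounds named here, no measured pair shows this exact exchange, so the expected step rests only on the spread of the three values, from the lowest at compound 3 up to compound 2. A modest rise, possibly within the scatter, is expected, and the step is expected to be a number 9.2 percentage points higher from compound 3 to compound 4 (within the scatter) in this assay. Compound 4 is therefore estimated at 62%, with a range from 40% to 80%.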

Compound 4, a percentage reported as inhibition, at one concentration (the size of the read-out at that concentration, not a potency): 30.8%
For compound 4 the middle estimate is 31.2 percentage points above the measured one; measured number outside the range, below it.
By their numbers in this assay, from the lowest: compound 4; then compound 3; then compound 1; then compound 2.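

In this assay, placing methyl(2-(piperidin-1-yl)ethyl)amino in place of ethyl((pyridin-4-yl)methyl)amino on an aromatic carbon gives a number 22 percentage points lower from compound 3 to compound 4 (beyond the scatter). This shows that the read-out responds to what this group contains at this place, meta to a large group, even though the counts of heavy atoms, hydrogen-bond donors and hydrogen-bond acceptors stay the same, so those counts alone do not settle the outcome here. The aromatic ring, the chain carrying it and the small alkyl group on the nitrogen all change in this one step, and no measurement at hand explains the fall or assigns it to any one of these parts.

Still open, from the compounds shown here alone, is whether the six-membered non-aromatic ring itself matters most, which a morpholine ring on the same two-carbon chain, or a simple dimethylamino group at the end of that chain, could help to test. Also open, going by these compounds, is whether methyl(2-(piperidin-1-yl)ethyl)amino would give a similar read-out at another place on the aromatic ring of carbon only.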